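Chain lengthening at the sulfur across two pairs

A few compounds are considered here, and "the series" means these few. Any claim that something is new, unique, unknown or untested is made for them only; others in the source may bear on it.

Compound 1 `CCSc1nnc(Cc2ccccc2Oc2ccccc2)[nH]1` is the reference for the first pair. In a functional assay on the whole organism (strain NMRI) with Mus musculus as the target, with a stated time of 60 min, at a dose of 20 mg/kg by the intraperitoneal route (a lower number here means a weaker effect, a higher number a stronger effect of the compound at the dose given), compound 1 gives 169%. Compound 2 `CCCSc1nnc(Cc2ccccc2Oc2ccccc2)[nH]1` differs from compound 1 by methyl in place of hydrogen on a saturated chain carbon, two bonds along the chain from a sulfur
. Within the data shown here, the step between them, a number 11 percentage points lower from compound 1 to compound 2 (beyond the scatter), is the only measured instance of this change so far.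

Compound 3 `CCSc1nnc(Cc2ccc(Cl)cc2Oc2ccccc2Cl)[nH]1` carries a different core; the difference between the two cores is not broken down here. In this assay compound 3 gives 174%, which sits within the scatter of the value of compound 1. Compound 2 gives 158%; the gap from compound 2 up to compound 3 lies beyond the scatter. No order between compound 3 and compound 1 can be read from this.

Compound 4 `CCCSc1nnc(Cc2ccc(Cl)cc2Oc2ccccc2Cl)[nH]1` has not yet been measured. It differs from compound 3 by methyl in place of hydrogen on a saturated chain carbon, two bonds along the chain from a sulfur
. The place is the same as between compound 1 and compound 2, word for word, so this is the same change, now made on the core of compound 3 instead of the core of compound 1.

Among the measured compounds shown here, the expectation for compound 4 rests on a single precedent, because a number 11 percentage points lower from compound 1 to compound 2 (beyond the scatter) is the only step that tells how this change reads in this assay; this step is taken over unchanged. The step from compound 3 to compound 4 is therefore expected to be a number 11 percentage points lower from compound 3 to compound 4 (beyond the scatter). For compound 4 the estimate in this assay is 163%, with a range from 148% to 178% that allows for the change landing differently on the second core.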

Compound 4, a percentage reported as activity, at one dose (the size of the read-out at that dose, not a potency): 134%
Compound 4: the middle estimate sits 29 percentage points above what was measured; the measured number lies below the stated range.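

On the core of compound 3, the change from ethylsulfanyl to propylsulfanyl reads as a number 40 percentage points lower from compound 3 to compound 4 (beyond the scatter) in this assay. The direction matches that of the pair on the core of compound 1, but the size of the step does not carry over from one core to the other: the same change on two cores in this assay, a number 11 percentage points lower (beyond the scatter) from compound 1 to compound 2 and a number 40 percentage points lower (beyond the scatter) from compound 3 to compound 4, 29 percentage points apart, beyond the scatter of two such steps

For this series, the step for this change therefore has to be read as dependent on the core, and a step measured on one core gives the direction on the other but not a usable size. Among these compounds, with only two pairs, this does not show which part of the difference between the two cores goes with the larger step, how the change would read on any further core, or why the two steps differ.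

The compounds shown leave open whether a single chlorine on the core of compound 1 would already give the larger step or whether both chlorines of the core of compound 3 are needed. They also leave open how a longer chain such as butylsulfanyl, a branched isopropylsulfanyl group or a chain ending in an amine would read on either core.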